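A Ring Swap on an Aromatic Nitrogen, Expected Effect

The source may report more compounds than this note shows. Statements on the series, on what has been measured and on what is new or still open speak of the compounds shown alone.

Of the compounds shown here, three have been measured in a functional assay on U2OS cells with metabotropic glutamate receptor 5 (Homo sapiens) as the target, read by calcium flux; on this read-out lower numbers stand for smaller maximal responses and higher numbers for larger maximal responses. Compound 1 `Fc1ccc(-c2nc(-c3ccc4c(c3)nnn4C3CCCC3)no2)cc1` gives 51%, compound 2 `Fc1ccc(-c2noc(C3CCc4c(nnn4-c4ccc(F)cc4)C3)n2)cc1` gives 106%, and compound 3 `CN1CCC(n2nnc3c2CCC(c2nc(-c4ccc(F)cc4)no2)C3)CC1` gives 91%. Compound 3 thus holds the second highest of the three numbers: its nearest neighbour is compound 2, which sits above it, while compound 1 lies furthest away, well below it. Within the data shown here, the only single-place step among the measured compounds is a number 15 percentage points lower from compound 2 to compound 3 (beyond the scatter), a modest change that lies beyond the scatter.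

Compound 4 `CC1(n2nnc3c2CCC(c2nc(-c4ccc(F)cc4)no2)C3)CCOCC1` differs from compound 3 in the same region: 4-methyloxan-4-yl in place of 1-methylpiperidin-4-yl on an aromatic nitrogen. Both groups are six-membered non-aromatic rings with one hetero atom and one hydrogen-bond acceptor. Because a number 15 percentage points lower from compound 2 to compound 3 (beyond the scatter) was only modest for a larger swap at this position, compound 4 is expected to stay close to compound 3, with an expected step of a number 1 percentage points lower from compound 3 to compound 4 (within the scatter) that may well fall within the scatter. Compound 4 is therefore estimated to give 90% in this assay, within a range from 70% to 110%.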

Compound 4, largest response reached (reported as percent of maximum), in percent of the reference or control that the assay uses: 103%
The estimate for compound 4 lay 13 percentage points below the measured number, and the stated range covers the measured number.
By their numbers in this assay, from the lowest: compound 1; then compound 3; then compounds 4 and 2 (each within the scatter of the next).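

The swap of 1-methylpiperidin-4-yl for 4-methyloxan-4-yl keeps the ring size and the counts of heavy atoms and hydrogen-bond acceptors, yet a number 12 percentage points higher from compound 3 to compound 4 (beyond the scatter) shows that the response at this position still moves. A non-aromatic ring can also match 4-fluorophenyl here, with a number 3 percentage points lower from compound 2 to compound 4 (within the scatter) for 4-methyloxan-4-yl, although compound 3 shows that not every such ring does. No measurement is available that explains the difference between these two rings.

The two groups differ both in the ring hetero atom and in where the methyl group sits, so plain oxan-4-yl would be needed to tell which difference goes with the step. On these data alone, how an open chain such as tert-butyl would read on this aromatic nitrogen also remains open.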